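A few compounds are considered here, and "the series" means these few. Any claim that something is new, unique, unknown or untested is made for them only; others in the source may bear on it.

Measured compounds:
compound 1 `N#CCCCn1c(Cn2c(=O)n(-c3ccncc3)c3ccncc32)cc2cc(Cl)ccc21`: > 50000 nM
compound 2 `CC(C)(O)CCCn1c(Cn2c(=O)n(C3CC3)c3ccncc32)nc2nc(Cl)ccc21`: > 50000 nM

In an ADME assay on HeLa cells (Homo sapiens) for cytotoxicity, read by ATP content, with a stated time of 3 days (on this read-out higher numbers stand for lower toxicity in this test and lower numbers for higher toxicity in this test), compound 1 gives > 50000 nM, which is a limit of the assay and not a number. Compound 2 likewise returns a limit of the assay in this assay, > 50000 nM. For the measured compounds named here, compound 1 therefore stands where the only other measured compound stands, since both values sit at the limit of > 50000 nM in this assay, at which 2 of the 2 values shown sit, and no step between measured compounds can be counted from them. Compound 3 `N#CCCCn1c(Cn2c(=O)n(-c3ncccn3)c3ccncc32)cc2cc(Cl)ccc21` has not yet been measured in this assay. It differs from compound 1 in one place: pyrimidin-2-yl in place of pyridin-4-yl on an aromatic nitrogen. Both measured values rest at the limit of > 50000 nM in this assay, at which 2 of the 2 values shown sit, and no evidence on this change exists. The step is expected to be a number no higher from compound 1 to compound 3 (the limit leaves the size open), none beyond the usual scatter. Compound 3 is thus estimated to give about 50000 nM in this assay, within 25000 nM to 100000 nM, and most probably again as a limit.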

Compound 3, half-maximal cytotoxic concentration: > 50000 nM
Compound 3 was reported as a limit; the forecaster's own chance of this, stated with the estimate: 85%; the middle value lies on the limit itself.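

For the compounds shown here, no step from compound 1 to compound 3 can be read in this assay, since both results are limits of the assay and not numbers: the limit of > 50000 nM in this assay, at which 3 of the 3 values shown sit. The compounds shown leave open whether pyrimidin-2-yl in place of pyridin-4-yl on an aromatic nitrogen changes the read-out in this assay at all.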